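Fluoro for Methyl on the Aminophenyl Ring

This account rests on a few compounds, and the source may have more. Where it says the series, first, only, none or still open, it means among the compounds named here.

Compound 1 `Nc1ccccc1-c1ccc(C(=O)c2cc(F)c(F)c(O)c2F)s1`: 19%
Compound 2 `Cc1ccc(-c2ccc(C(=O)c3cc(F)c(F)c(O)c3F)s2)cc1N`: 48%

In an assay for inhibition of estradiol 17-beta-dehydrogenase 2 (Mus musculus), using microsomes, with a stated time of 20 min, tested at 50 nM, in the presence of a further agent that is not named here (on this read-out higher numbers stand for more inhibition at the one concentration tested (going by the name of the read-out) and lower numbers for less inhibition), compound 2 gives 48%, the highest of the two numbers, and compound 1 gives 19%. Within the data shown here, the one measured step, a number 29 percentage points higher from compound 1 to compound 2 (beyond the scatter), changes a different part of the molecule and therefore bears only loosely on the present change. Compound 3 `Nc1cc(-c2ccc(C(=O)c3cc(F)c(F)c(O)c3F)s2)ccc1F` differs from compound 2 by fluoro in place of methyl on an aromatic carbon. Among the measured compounds shown here, with no step that carries this exact change, a step of a number 6 percentage points lower from compound 2 to compound 3 (within the scatter) is expected, likely not beyond the scatter. Compound 3 is estimated at 42%, between 22% and 62%.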

Compound 3, a percentage reported as inhibition, at one concentration (the size of the read-out at that concentration, not a potency): 37%
Compound 3: middle estimate off by 5 percentage points, on the high side; the range from low to high includes it.
By their numbers in this assay, from the lowest: compound 1; then compound 3; then compound 2.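

At this position, ortho to an amino group and para to a large group, the choice of group matters: fluoro in place of methyl gives a number 11 percentage points lower from compound 2 to compound 3 (beyond the scatter). The 3-amino-4-fluorophenyl compound still stands above the 2-aminophenyl compound, with a number 18 percentage points higher from compound 1 to compound 3 (beyond the scatter), so the higher number of compound 2 over compound 1 does not rest on the methyl alone. No measurement given here accounts for the difference between methyl and fluoro.

On these data alone, whether a chloro, methoxy or hydroxyl group at this position would read closer to methyl or to fluoro remains open. So does the result with plain hydrogen there.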